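The compounds below may be only part of what the source reports. "The series", "measured", "known", "first", "only" and "open" are said of these compounds alone.

Among the compounds with values here, compound 2, `CC1(C)Cc2c(sc(NC(=O)c3cc(C(F)(F)F)n[nH]3)c2C(N)=O)C(C)(C)O1`, gives the lowest of the two numbers recorded in an assay on cells for positive allosteric modulation of Cystic fibrosis transmembrane conductance regulator variant F508del (Homo sapiens), with stated times of 10 min and 7 s, in the presence of a further agent that is not named here (on this read-out lower numbers stand for an effect already at smaller amounts and higher numbers for an effect only at larger amounts of compound), namely 3 nM; the only other measured compound, compound 1, `CC1(C)Cc2c(sc(NC(=O)Cc3ccn[nH]3)c2C(N)=O)C(C)(C)O1`, gives 136 nM. Within the data shown here, the single measured step, a 45-fold lower number from compound 1 to compound 2 (1.66 log units; beyond the scatter), joins two changes at once: the carbonyl substituent goes from (1H-pyrazol-5-yl)methyl to 3-(trifluoromethyl)-1H-pyrazol-5-yl, so how much of that step belongs to the trifluoromethyl alone cannot be read from the data.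

Compound 3, `Cc1cc(C(=O)Nc2sc3c(c2C(N)=O)CC(C)(C)OC3(C)C)[nH]n1`, keeps the direct ring-to-carbonyl link of compound 2 and differs only in methyl in place of trifluoromethyl on an aromatic carbon. Among the measured compounds shown here, the step from compound 1 to compound 2 bears on this change only in part, and no step separates the two parts. On these data alone, compound 3 is therefore expected to give a somewhat higher number than compound 2, a step of a 4.0-fold higher number from compound 2 to compound 3 (0.60 log units; beyond the scatter), with a wide band, since the part of a 45-fold lower number from compound 1 to compound 2 (1.66 log units; beyond the scatter) that the trifluoromethyl carries is unknown. Compound 3 is estimated at 12 nM, between 3 nM and 50 nM.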

Compound 3, half-maximal effective concentration: 13 nM
Compound 3: the middle estimate sits 1.1-fold (0.03 log units) below what was measured; the measured number falls inside the stated range.
By their numbers in this assay, from the lowest: compound 2; then compound 3; then compound 1.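

Swapping only the group on the aromatic carbon, with the direct ring-to-carbonyl link kept, gives in this assay a modest step, a 4.3-fold higher number from compound 2 to compound 3 (0.64 log units; beyond the scatter), so trifluoromethyl accounts for only part of the earlier gain. The large step of a 10-fold lower number from compound 1 to compound 3 (1.02 log units; beyond the scatter) shows that most of that gain remains with methyl in place of trifluoromethyl, once 3-methyl-1H-pyrazol-5-yl replaces (1H-pyrazol-5-yl)methyl on the carbonyl carbon. Nothing on hand explains why either step has the size it does.

On these data alone, how that large step divides between the direct link and the methyl stays open, and an unsubstituted 1H-pyrazol-5-yl on the carbonyl carbon would separate the two. Also open, as far as these compounds go, is how an ethyl, a chlorine or an amine on the same aromatic carbon would compare with methyl and trifluoromethyl.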